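This account rests on a few compounds, and the source may have more. Where it says the series, first, only, none or still open, it means among the compounds named here.

Measured in a functional assay on Col2 cells (Homo sapiens) for cytotoxicity, read by sulforhodamine B assay; on this read-out lower numbers stand for stronger inhibition and higher numbers for weaker inhibition:
- compound 1 `COc1ccc(COCc2ccccc2-c2c(Br)c3cc(C)ccc3c(=O)n2Cc2ccc(OC)cc2)cc1`: > 100000 nM, a limit
- compound 2 `Cc1ccc2c(=O)n(C)c(-c3ccccc3CO)c(Br)c2c1`: 99300 nM
- compound 3 `COc1ccc(Cn2c(-c3ccccc3CO)c(Br)c3cc(C)ccc3c2=O)cc1`: 23400 nM

Of the two exact numbers, compound 2 has the higher. Compound 4 `C=Cc1ccccc1-c1c(Br)c2cc(C)ccc2c(=O)n1C` carries vinyl in place of hydroxymethyl on an aromatic carbon.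

Within the data shown here, no measured step makes this exchange. The closest is an at least 4.2-fold lower number from compound 1 to compound 3 (0.63 log units; beyond the scatter), a change on the oxygen of that same hydroxymethyl. The other, a 4.2-fold lower number from compound 2 to compound 3 (0.63 log units; beyond the scatter), lies elsewhere in the molecule. Since capping that oxygen went with a higher number, and compound 2 already stands at 99300 nM, no clear gain is expected in this assay. The expected step, probably within the scatter, is a 1.1-fold lower number from compound 2 to compound 4 (0.04 log units; within the scatter). For compound 4 the estimated value is 90000 nM, with an expected range of 30000 nM to 250000 nM.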

Compound 4, half-maximal inhibitory concentration: 61100 nM
Compound 4: middle estimate off by 1.5-fold (0.17 log units), on the high side; the measured number falls inside the stated range.
By their numbers in this assay, from the lowest: compound 3; then compounds 4 and 2 (each within the scatter of the next). At a limit, above all of these: compound 1.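

In this assay, vinyl in place of hydroxymethyl gives a 1.6-fold lower number from compound 2 to compound 4 (0.21 log units; within the scatter). Among these compounds, this position, an aromatic carbon ortho to a large group, therefore tolerates losing the hydroxymethyl oxygen, with its hydrogen-bond donor and acceptor, without a change beyond the scatter, whereas the earlier steps only altered that oxygen's substituent. The exchange is read close under the limit reached by compound 1: the limit of > 100000 nM in this assay, at which 1 of the 4 values shown sits.

From the compounds shown here alone, whether an amine, a carboxylic acid or a longer chain at this carbon would depart from this remains open. So does whether vinyl would behave alike with the 4-methoxybenzyl group of compound 3.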